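This account rests on a few compounds, and the source may have more. Where it says the series, first, only, none or still open, it means among the compounds named here.

Three compounds share one core and differ only in the group carried on the ring attached through the carbonyl-bound chain carbon. In an assay on microsomes from brain for inhibition of Fatty-acid amide hydrolase 1 (Rattus norvegicus), read by fluorescence and HPLC, with a stated time of 60 min (on this read-out lower numbers stand for stronger inhibition and higher numbers for weaker inhibition), compound 1 `CCCCCCCCc1ccc(OCC(=O)Cn2nnc(-c3ccccc3Cl)n2)cc1` gives 32 nM, compound 2 `CCCCCCCCc1ccc(OCC(=O)Cn2nnc(-c3ccc(C(=O)OC)cc3)n2)cc1` gives 29 nM, and compound 3 `CCCCCCCCc1ccc(OCC(=O)Cn2nnc(C(=O)O)n2)cc1` gives 41 nM. Compound 3 stands highest of the three, but a 1.3-fold higher number from compound 1 to compound 3 (0.11 log units; within the scatter) and a 1.4-fold higher number from compound 2 to compound 3 (0.15 log units; within the scatter) both lie within the scatter, so the three values cannot be ordered. Compound 4 `CCCCCCCCc1ccc(OCC(=O)Cn2nnnc2C)cc1` arises from compound 3 by 5-methyl-1H-tetrazol-1-yl in place of 5-carboxy-2H-tetrazol-2-yl on a saturated chain carbon bound to a carbonyl carbon. The steps bearing on this, the replacement of either aryl group by carboxy, were each too small to resolve, so a further change of the ring substituent is expected to give at most a step within the scatter in this assay, with a slight lean toward a higher number. Compound 4 is therefore estimated at 50 nM, between 20 nM and 130 nM, meaning a 1.2-fold higher number from compound 3 to compound 4 (0.09 log units; within the scatter).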

Compound 4, half-maximal inhibitory concentration: 41 nM
Compound 4: middle estimate off by 1.2-fold (0.09 log units), on the high side; measured number inside the range.
By their numbers in this assay, from the lowest: compounds 2, 1, 3 and 4 (each within the scatter of the next).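

The earlier compounds shown here all kept 5-substituted 2H-tetrazol-2-yl groups, whereas compound 4 changes the group itself on the saturated chain carbon bound to a carbonyl carbon. In this assay, replacing 5-carboxy-2H-tetrazol-2-yl with 5-methyl-1H-tetrazol-1-yl removes the carboxy group and its hydrogen-bond donor, yet gives no resolved difference (no change at the digits printed from compound 3 to compound 4 (within the scatter)). No measurement shown explains this result. Going by these compounds alone, the single step cannot separate the carboxy-to-methyl exchange from the switch from 2H-tetrazol-2-yl to 1H-tetrazol-1-yl. It also leaves open whether 5-methyl-2H-tetrazol-2-yl or a simple amine at this position would fit the same range.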